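Trading a Nitro Group for a Selenium-Bearing Chain

This account rests on a few compounds, and the source may have more. Where it says the series, first, only, none or still open, it means among the compounds named here.

Of the compounds shown here, two have been measured in a functional assay on A549 cells (Homo sapiens) for antiproliferative activity, read by MTT assay, with a stated time of 48 h; on this read-out higher numbers stand for weaker inhibition and lower numbers for stronger inhibition. Compound 1 `COc1ccc(N(C)c2ccnc(Cl)n2)cc1F` gives 651 nM, and compound 2 `COc1ccc(N(C)c2ccnc(Cl)n2)cc1[N+](=O)[O-]` gives 3780 nM, the higher of the two numbers. For the measured compounds named here, the single measured step, a 5.8-fold higher number from compound 1 to compound 2 (0.76 log units; beyond the scatter), is the only guide available.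

Compound 3 `COc1ccc(N(C)c2ccnc(Cl)n2)cc1OCC[Se]C#N` differs from compound 2 by a group of 6 heavy atoms (3 carbon, 1 nitrogen, 1 oxygen, 1 selenium; no ring) in place of a group of 3 heavy atoms (1 nitrogen, 2 oxygen; no ring), on an aromatic carbon. Part of this change reverses the measured step: the nitro group that entered from compound 1 to compound 2 now leaves. Going by the values given here, the entering group of 6 heavy atoms has no counterpart among the measured compounds, so its own effect is unknown. A partial return toward the number of compound 1 is expected, with wide uncertainty, amounting to an expected step of a 2.5-fold lower number from compound 2 to compound 3 (0.40 log units; beyond the scatter) in this assay. The estimate for compound 3 is 1500 nM, within a range from 400 nM to 6000 nM.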

Compound 3, half-maximal inhibitory concentration: 463 nM
Estimate against measurement, compound 3: 3.2-fold (0.51 log units) above, and the stated range covers the measured number.
By their numbers in this assay, from the lowest: compounds 3 and 1 (each within the scatter of the next); then compound 2.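

In this assay, putting the selenium-bearing chain of 6 heavy atoms in place of the nitro group gives an 8.2-fold lower number from compound 2 to compound 3 (0.91 log units; beyond the scatter) and shows that this position, ortho to a methoxy group, can carry a chain and not only a small group. Replacing the single fluorine atom with the same chain gives a 1.4-fold lower number from compound 1 to compound 3 (0.15 log units; within the scatter) and so leaves the two compounds indistinguishable on this read-out. Among the three compounds, therefore, only the one with the nitro group stands apart, with the weaker inhibition.

Nothing available explains why these numbers differ. From the compounds shown here alone, it remains open whether the selenium atom or the nitrile end matters at all, and whether a plain ethoxy group or a longer chain carrying only carbon atoms would give a similar number.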